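A few compounds are considered here, and "the series" means these few. Any claim that something is new, unique, unknown or untested is made for them only; others in the source may bear on it.

Going by the values given here, compound 1 `Clc1ccc(C2CC(c3ccccc3)=NN2c2ccccc2)cc1` gives 1170 nM in an assay for inhibition of cathepsin H (Capra hircus), using Lineweaver-Burk analysis (a lower number here means a stronger inhibitor, a higher number a weaker inhibitor), the lowest of the three numbers measured so far. Compound 2 `Brc1ccc(C2CC(c3ccccc3)=NN2c2ccccc2)cc1` gives 3160 nM, and compound 3 `Cc1ccc(C2CC(c3ccccc3)=NN2c2ccccc2)cc1` gives 4180 nM. Within this small set, a 2.7-fold higher number from compound 1 to compound 2 (0.43 log units; beyond the scatter) and a 3.6-fold higher number from compound 1 to compound 3 (0.55 log units; beyond the scatter), while a 1.3-fold higher number from compound 2 to compound 3 (0.12 log units; within the scatter). Compound 4 `Clc1ccc(C2CC(c3ccccc3)=NN2)cc1` differs from compound 1 in one place: hydrogen in place of phenyl on an amine nitrogen in a ring. On these data alone, all three measured steps swap the group on an aromatic carbon of a side ring and leave the amine nitrogen in the ring untouched, so none of them bears on this change, and the size and direction of the step remain open; the expectation rests on compound 1 alone and is therefore wide. Compound 4 is estimated at 2500 nM, with a range from 700 nM to 9000 nM, which would mean a 2.1-fold higher number from compound 1 to compound 4 (0.33 log units; beyond the scatter).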

Compound 4, inhibition constant: 1560 nM
For compound 4 the middle estimate is 1.6-fold (0.20 log units) above the measured one; low and high end bracket the measured number.
By their numbers in this assay, from the lowest: compounds 1 and 4 (each within the scatter of the next); then compounds 2 and 3 (each within the scatter of the next).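

In this assay, hydrogen in place of phenyl on the amine nitrogen in the ring gives a 1.3-fold higher number from compound 1 to compound 4 (0.12 log units; within the scatter). Going by these compounds alone, the number seen for compound 1 therefore does not depend on that phenyl, a point the earlier steps could not address, since they changed only the group on an aromatic carbon. Nothing measured here explains this result. Other groups on this nitrogen, such as methyl, acetyl or benzyl, remain open. So does whether hydrogen there would give a similar result with bromo or methyl in place of chloro.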